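Swapping 2-methylphenyl for 4-chlorophenyl at the measuring limit

The source may report more compounds than this note shows. Statements on the series, on what has been measured and on what is new or still open speak of the compounds shown alone.

In a functional assay on MDA-MB-231 cells (Homo sapiens) for inhibition, read by MTT assay, with a stated time of 72 h (on this read-out lower numbers stand for stronger inhibition and higher numbers for weaker inhibition), compound 1 `Cc1ccc(-c2cc(C(=O)N3CCC4(CC3)CC(=O)c3nn(C(C)(C)C)cc3O4)c3ccccc3n2)cc1` gives > 10000 nM, which is a limit and not a number. Compound 2 `Cc1ccccc1-c1cc(C(=O)N2CCC3(CC2)CC(=O)c2nn(C(C)(C)C)cc2O3)c2ccccc2n1` gives > 10000 nM, likewise only a limit. The pair therefore stands at the limit of > 10000 nM in this assay, at which 2 of the 2 values shown sit, and compound 2 has no readable number to build on.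

Compound 3 `CC(C)(C)n1cc2c(n1)C(=O)CC1(CCN(C(=O)c3cc(-c4ccc(Cl)cc4)nc4ccccc34)CC1)O2` carries the next change: 4-chlorophenyl in place of 2-methylphenyl on an aromatic carbon, with 4-chlorophenyl in place of 2-methylphenyl on an aromatic carbon, next to the ring nitrogen. Among the compounds with values here, the only measured step that bears on this exchange is a step that the two limits leave unreadable from compound 1 to compound 2, also a change of the aryl group, and its size cannot be read. Resting on that step, no shift beyond the scatter is expected in this assay in either direction, and another limit is the likeliest report. The estimated step is a step that the limit leaves unreadable from compound 2 to compound 3. Compound 3 is expected at 12000 nM, with an estimated range of 4000 nM to 30000 nM.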

Compound 3, half-maximal inhibitory concentration: > 10000 nM
Compound 3 was reported as a limit; the forecaster's own chance of this, stated with the estimate: 80%; the middle value does not contradict the limit.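

Within the data shown here, compound 3 joins compound 1 and compound 2 at a limit in this assay and no new step among the three can be read: the limit of > 10000 nM in this assay, at which 3 of the 3 values shown sit. The compounds shown leave open whether 4-methylphenyl, 2-methylphenyl and 4-chlorophenyl differ at all in inhibition, and whether any aryl group on the shared core gives a readable number.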